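The source may report more compounds than this note shows. Statements on the series, on what has been measured and on what is new or still open speak of the compounds shown alone.

Measured so far in a functional assay on the whole organism with Canis familiaris (Canis lupus familiaris) as the target; a higher number here means that more compound is needed for the effect, a lower number that less compound is needed:
- compound 1 `COC(=O)CC/C=C\CC[C@H]1C(=O)C[C@@H](O)[C@@H]1/C=C/C[C@@](C)(O)/C=C/C1=CCCC1`: 0.00002 mg/kg
- compound 2 `C=C/C=C/[C@](C)(O)C/C=C/[C@H]1[C@H](O)CC(=O)[C@@H]1CC/C=C\CCC(=O)OC`: 0.000007 mg/kg
- compound 3 `C=C/C(C)=C/[C@](C)(O)C/C=C/[C@H]1[C@H](O)CC(=O)[C@@H]1CC/C=C\CCC(=O)OC`: 0.00071 mg/kg

Compound 3 gives the highest number of the three. Its nearest neighbour is compound 1, with a 36-fold higher number from compound 1 to compound 3 (1.55 log units; beyond the scatter); its furthest is compound 2, with a 100-fold higher number from compound 2 to compound 3 (2.01 log units; beyond the scatter). Among the measured compounds shown here, the one remaining step among the measured compounds is a 2.9-fold lower number from compound 1 to compound 2 (0.46 log units; beyond the scatter), a modest move.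

Compound 4 `CCCCC(C)(O)C/C=C/[C@H]1[C@H](O)CC(=O)[C@@H]1CC/C=C\CCC(=O)OC` differs from compound 3 as follows:
1-hydroxy-1-methylpentyl in place of 1-hydroxy-1,3-dimethylpenta-2,4-dien-1-yl on a saturated chain carbon bound to a double-bonded chain carbon

For the measured compounds named here, no measured step matches this change. The two large steps, from compound 1 and from compound 2 to compound 3, each concern a methyl entering on the diene, and the modest step from compound 1 to compound 2 concerns a ring leaving the end of the chain; none removes the double bonds of the chain outright. Compound 4 gives up the methyl that accompanied the large rise into compound 3, but it also gives up both double bonds of the chain, for which nothing measured here speaks. The expectation is therefore a step of uncertain direction and modest size, a 2.4-fold lower number from compound 3 to compound 4 (0.37 log units; beyond the scatter), with a wide range.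

Compound 4 is estimated at 0.0003 mg/kg in this assay, expected to fall between 0.00003 mg/kg and 0.003 mg/kg.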

Compound 4, dose for half-maximal effect: 0.000023 mg/kg
Compound 4: middle estimate off by 13-fold (1.12 log units), on the high side; measured number below the stated range.
By their numbers in this assay, from the lowest: compound 2; then compounds 1 and 4 (each within the scatter of the next); then compound 3.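

In this assay, the saturated 1-hydroxy-1-methylpentyl on a saturated chain carbon bound to a double-bonded chain carbon replaces the 1-hydroxy-1,3-dimethylpenta-2,4-dien-1-yl and gives a 31-fold lower number from compound 3 to compound 4 (1.49 log units; beyond the scatter), which shows that the double bonds of this chain are not needed for a low number among the compounds shown. Set against the unmethylated diene, the same saturated chain gives only a modest change, a 3.3-fold higher number from compound 2 to compound 4 (0.52 log units; beyond the scatter), and set against the chain ending in a cyclopentenyl ring it gives a 1.2-fold higher number from compound 1 to compound 4 (0.06 log units; within the scatter), a difference within the scatter, so this position accepts a diene, a ring-ended chain and a saturated chain alike, with compound 3 as the one exception at the high end of the series. No independent information bears on why the methylated diene stands apart from the other three chains.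

Still open, on these data alone, is whether a methyl on the saturated pentyl chain would raise the number as the methyl on the diene does, and how a longer chain such as octyl or a terminal phenyl ring would read at this place. The carbon bearing the hydroxyl has no defined stereocentre in compound 4, so the contribution of each of its two forms also remains unresolved.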